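Methyl on the core: compound 2 to compound 4

The source may hold more compounds than are shown below. What is called first, only, known or untested is meant among the compounds shown, and "the series" means these compounds.

Measured so far in an ADME assay on HEL cells (Homo sapiens) for cytotoxicity, with a stated time of 3 days; a higher number here means that more compound is tolerated, a lower number that less compound is tolerated:
compound 1 `Cc1cc(-c2ccc(O)cc2)c2ncc(CSCCc3ccccc3)n2c1` gives 20 ug/mL
compound 2 `c1ccc(CCSCc2cnc3ccc(-c4ccccc4)cn23)cc1` gives 4 ug/mL
compound 3 `Cc1cc(-c2ccsc2)c2ncc(CSCCc3ccccc3)n2c1` gives 100 ug/mL

Compound 2 stands lowest of the three numbers in this assay; its nearest neighbour is compound 1, and compound 3 lies furthest from it, both steps beyond the scatter. Compound 4 `Cc1cc(-c2ccccc2)cn2c(CSCCc3ccccc3)cnc12` has not been measured in this assay. It differs from compound 2 in one place: methyl in place of hydrogen on an aromatic carbon. The methyl enters on an aromatic carbon of a six-membered aromatic ring with one nitrogen, part of a fused system of two rings, two atoms from the ring nitrogen.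

Within the data shown here, the only measured step, a 5.0-fold higher number from compound 1 to compound 3 (0.70 log units; beyond the scatter), swaps the aryl group on compound 1 and compound 3 and does not touch the methyl; both of those compounds carry the methyl already, so no step here isolates its effect. Compound 1 and compound 3, the two methyl-bearing compounds, each show a higher number than compound 2, but the aryl differences confound that comparison. A change of this size on the core might plausibly shift the number in this assay somewhat, with direction uncertain; the expected step is a 2.5-fold higher number from compound 2 to compound 4 (0.40 log units; beyond the scatter). For compound 4 the estimated value in this assay is 10 ug/mL, within 3 ug/mL to 40 ug/mL.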

Compound 4, minimum cytotoxic concentration: 20 ug/mL
The estimate for compound 4 lay 2.0-fold (0.30 log units) below the measured number, within the range that was stated.
By their numbers in this assay, from the lowest: compound 2; then compounds 1 and 4 (each within the scatter of the next); then compound 3.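

In this assay, among these compounds, methyl in place of hydrogen on an aromatic carbon gives a 5.0-fold higher number from compound 2 to compound 4 (0.70 log units; beyond the scatter), the first step that isolates this change, with the phenyl group and the rest of the shared core the same in both compounds. A single added carbon at this position, two atoms from the ring nitrogen, is therefore enough to move the number beyond the scatter, and the move is towards more compound tolerated. The result also supplies a phenyl reference among the methyl-bearing compounds: in this assay compound 4 gives 20 ug/mL, compound 1 gives the same printed 20 ug/mL, and compound 3 gives 100 ug/mL.

No measurement at hand bears on the reason for this step. Open, from the compounds shown here alone, is whether an ethyl group, a methoxy group or an amine on this carbon would move the number the same way, and whether the methyl step carries over when the phenyl group is replaced by 4-hydroxyphenyl or thiophen-3-yl.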